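The source may report more compounds than this note shows. Statements on the series, on what has been measured and on what is new or still open speak of the compounds shown alone.

Measured in a functional assay on the whole organism (strain CF-1) for inhibition, with Mus musculus as the target; on this read-out higher numbers stand for an effect only at larger amounts of compound and lower numbers for an effect already at smaller amounts:
compound 1 `Cc1nnc(CN2CCCC2)n1-c1ccc(Cl)cc1C(O)c1ccccc1`, 14 mg/kg
compound 2 `Cc1nnc(CN2CCCC2)n1-c1ccc(Cl)cc1C(=O)c1ccccc1Cl`, 4 mg/kg
compound 3 `Cc1nnc(CN2CCCC2)n1-c1ccc(Cl)cc1Cc1ccccc1`, a limit of the assay, > 100 mg/kg

Compound 2 holds the lowest of the two numbers shown; its nearest neighbour is compound 1, seen in a 3.5-fold lower number from compound 1 to compound 2 (0.54 log units; beyond the scatter). Compound 3 sits at the limit of > 100 mg/kg in this assay, at which 1 of the 3 values shown sits, so only a limit is known for it. The steps to compound 3 are an at least 7.1-fold higher number from compound 1 to compound 3 (0.85 log units; beyond the scatter) and an at least 25-fold higher number from compound 2 to compound 3 (1.39 log units; beyond the scatter).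

Compound 4 `Cc1nnc(CN(C)C)n1-c1ccc(Cl)cc1C(=O)c1ccccc1Cl` differs from compound 2 by dimethylamino in place of pyrrolidin-1-yl on a saturated chain carbon bound to an aromatic carbon. All three measured steps change the hydroxy(phenyl)methyl, (2-chlorophenyl)carbonyl or benzyl group on an aromatic carbon; the (pyrrolidin-1-yl)methyl part is the same in compounds 1, 2 and 3. Among the measured compounds shown here, no measured step therefore bears on the change to compound 4, and no step beyond the scatter is expected in this assay from compound 2 to compound 4, in either direction. The number for compound 4 is estimated at 5 mg/kg, with a range from 2 mg/kg to 15 mg/kg. That estimate means a 1.3-fold higher number from compound 2 to compound 4 (0.10 log units; within the scatter).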

Compound 4, dose for half-maximal effect: 0.28 mg/kg
Estimate against measurement, compound 4: 18-fold (1.25 log units) above; measured number outside the range, below it.
By their numbers in this assay, from the lowest: compound 4; then compound 2; then compound 1. At a limit, above all of these: compound 3.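

In this assay, the group on the saturated chain carbon bound to an aromatic carbon proves to be a strong handle on the number: dimethylamino in place of pyrrolidin-1-yl gives a 14-fold lower number from compound 2 to compound 4 (1.15 log units; beyond the scatter). Compound 1, compound 2 and compound 3 all carry the (pyrrolidin-1-yl)methyl part and so showed only what the group on an aromatic carbon does; this second place in the shared core can now move the number too, with a ring-free amine giving the lowest number of the series. Nothing measured here gives a cause for this step.

Dimethylamino appears only together with the (2-chlorophenyl)carbonyl group, so it stays open whether the step would carry over to the hydroxy(phenyl)methyl group of compound 1. Also open, from the compounds shown here alone, is how methylamino, diethylamino or morpholin-4-yl would read at this place.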